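Swapping a fluorophenyl for cyclobutyl on the amide carbonyl

The source may report more compounds than this note shows. Statements on the series, on what has been measured and on what is new or still open speak of the compounds shown alone.

Compound 1, `Cc1cccc(Cn2c(CN3CCN(C(=O)c4cccnc4)CC3)nc3ccccc32)c1`: 24.5%
Compound 2, `Cc1ccc(C(=O)N2CCN(Cc3nc4ccccc4n3Cc3cccc(C)c3)CC2)cc1`: 64.9%
Compound 3, `Cc1cccc(Cn2c(CN3CCN(C(=O)c4ccc(F)cc4)CC3)nc3ccccc32)c1`: 27.1%

Three measured compounds share one core and differ only in the group attached to the carbonyl carbon. In an assay on isolated protein for inhibition of aldehyde dehydrogenase 1A1 (Homo sapiens), read by spectrophotometry, tested at 10 uM (on this read-out lower numbers stand for less inhibition and higher numbers for more inhibition at the one concentration tested (going by the name of the read-out)), compound 1 gives 24.5%, compound 2 gives 64.9%, and compound 3 gives 27.1%. Compound 3 stands second highest of the three: its value and that of compound 1 lie within the scatter of each other (a number 2.6 percentage points higher from compound 1 to compound 3 (within the scatter)), while compound 2 sits far above it (a number 37.8 percentage points lower from compound 2 to compound 3 (beyond the scatter)).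

Compound 4, `Cc1cccc(Cn2c(CN3CCN(C(=O)C4CCC4)CC3)nc3ccccc32)c1`, has not yet been measured. It differs from compound 3 in one place: cyclobutyl in place of 4-fluorophenyl on a carbonyl carbon. For the measured compounds named here, none of the measured steps exchanges an aromatic ring for a non-aromatic one at this position, so no step bears directly on this change. What the measured steps do show is that the group on the carbonyl carbon can move the read-out a great deal: a number 40.4 percentage points higher from compound 1 to compound 2 (beyond the scatter) and a number 37.8 percentage points lower from compound 2 to compound 3 (beyond the scatter). Going by the values given here, the one small step is a number 2.6 percentage points higher from compound 1 to compound 3 (within the scatter). Among the compounds with values here, with no direct precedent, the expectation for compound 4 is a step of a number 2.1 percentage points lower from compound 3 to compound 4 (within the scatter), that is, nothing beyond the scatter, but with wide uncertainty in either direction. Compound 4 is therefore estimated at 25%, with a range from 5% to 55%.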

Compound 4, a percentage reported as inhibition, at one concentration (the size of the read-out at that concentration, not a potency): 69.1%
Compound 4: middle estimate off by 44.1 percentage points, on the low side; the measured number lies above the stated range.
By their numbers in this assay, from the lowest: compounds 1 and 3 (each within the scatter of the next); then compounds 2 and 4 (each within the scatter of the next).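

In this assay, the group on the carbonyl carbon need not be aromatic for the read-out to be high: cyclobutyl in place of 4-fluorophenyl gives a number 42 percentage points higher from compound 3 to compound 4 (beyond the scatter), and cyclobutyl in place of pyridin-3-yl gives a number 44.6 percentage points higher from compound 1 to compound 4 (beyond the scatter). Yet aromatic and non-aromatic rings do not simply divide the series, since compound 2 goes against any such split: replacing its 4-methylphenyl with cyclobutyl gives a number 4.2 percentage points higher from compound 2 to compound 4 (within the scatter), so a four-membered carbon ring and a substituted six-membered aromatic ring land at the same level here. No measurement shown explains why cyclobutyl and 4-methylphenyl stand together, well apart from 4-fluorophenyl and pyridin-3-yl.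

The compounds shown leave open whether this level depends on the cyclobutyl ring itself, or whether cyclopropyl, cyclohexyl or an open chain such as isopropyl would read the same. They also leave open whether a ring holding an oxygen atom, such as oxetane, or an amine, such as piperidine, would keep the read-out, and how any of these would compare across a range of concentrations rather than at a single one.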